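Rearranging the cyanoguanidine tail on a pyridazinone core

The source may report more compounds than this note shows. Statements on the series, on what has been measured and on what is new or still open speak of the compounds shown alone.

Measured compounds:
compound 1 `N#CNC(=N)NCCCCCn1nc(-c2ccccc2)ccc1=O`: 31%
compound 2 `C/N=C(/NC#N)NCCCCn1nc(N2CCN(C)CC2)ccc1=O`: 7.9%

In a functional assay on the whole organism with Rattus norvegicus as the target, at a dose of 100 mg/kg (a higher number here means more inhibition at the dose given (going by the name of the read-out), a lower number less inhibition), compound 1 gives 31% and stands highest of the two numbers, while compound 2 gives 7.9%, a gap beyond the scatter. Compound 3 `C/N=C(\NC#N)NCCCCn1nc(-c2ccccc2)ccc1=O` has not been measured. It differs from compound 1 in a group of 7 heavy atoms (3 carbon, 4 nitrogen; no ring) in place of a group of 7 heavy atoms (3 carbon, 4 nitrogen; no ring), on a saturated chain carbon, four bonds along the chain from an aromatic nitrogen; the two have the same atoms, joined differently, and one hydrogen-bond donor fewer. Within the data shown here, no measured step isolates this change, so a moderate decrease is expected from compound 1 to compound 3, a number 9 percentage points lower from compound 1 to compound 3 (within the scatter). For compound 3 the expected value is 22%, with a range from 8% to 38%.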

Compound 3, a percentage reported as inhibition, in the whole organism at one dose (the size of the read-out at that dose, not a potency): 79%
Compound 3: middle estimate off by 57 percentage points, on the low side, and the stated range ends below it.
By their numbers in this assay, from the lowest: compound 2; then compound 1; then compound 3.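

In this assay, this position proves highly sensitive to how the same atoms are joined: with the group on the saturated chain carbon rearranged and one hydrogen-bond donor fewer, the result is a number 48 percentage points higher from compound 1 to compound 3 (beyond the scatter). Among these compounds, the earlier compounds offered no step at this position, so this is the first sign that the tail matters so much. Nothing at hand explains the step. The compounds shown leave open whether a urea or a carboxylic acid at this place would hold the inhibition in this assay. They also leave open how a longer chain carrying the same group would fare.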